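Swapping methoxy for fluoro on a steroid reductase binding compound

This account rests on a few compounds, and the source may have more. Where it says the series, first, only, none or still open, it means among the compounds named here.

Measured so far:
compound 1 `O=C(O)c1ccc(OC2CCN(C(=O)N(c3ccccc3)c3ccccc3)CC2)cc1`: 10%
compound 2 `COc1cc(C(=O)O)ccc1C=C1CCN(C(=O)C(C2CCCCC2)C2CCCCC2)CC1`: 5%

In an assay for inhibition of 3-oxo-5-alpha-steroid 4-dehydrogenase 1 (Homo sapiens), tested at 10 uM (on this read-out higher numbers stand for more inhibition at the one concentration tested (going by the name of the read-out) and lower numbers for less inhibition), compound 1 gives 10% and compound 2 gives 5%. The two numbers sit within the usual scatter of each other, so neither compound stands apart; both show little inhibition at this concentration. Compound 3 `O=C(O)c1ccc(C=C2CCN(C(=O)C(C3CCCCC3)C3CCCCC3)CC2)c(F)c1` follows from compound 2 by the change (fluoro in place of methoxy on an aromatic carbon). For the measured compounds named here, no measured pair shows this change, so its effect is unknown. Given the small number of compound 2 in this assay, the expected step of a number 2 percentage points higher from compound 2 to compound 3 (within the scatter) is none beyond the scatter. Compound 3 is therefore estimated at 7%, with a range of -5% to 20%.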

Compound 3, a percentage reported as inhibition, at one concentration (the size of the read-out at that concentration, not a potency): 12%
Beside the measured number, compound 3's estimate is 5 percentage points below it; the range from low to high includes it.
By their numbers in this assay, from the lowest: compounds 2, 1 and 3 (each within the scatter of the next).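

In this assay, fluoro in place of methoxy on this aromatic carbon, ortho to a large group and meta to a carboxy group, gives a number 7 percentage points higher from compound 2 to compound 3 (within the scatter). For the compounds shown here, this is the first reading of the swap, and it shows that exchanging these two groups at this position has no effect that stands clear of the usual scatter. No outside measurement bears on this result.

Going by these compounds, whether any group on this carbon can lift inhibition remains open, for example an amine or a hydroxy group. So does whether the same swap would behave alike on the core of compound 1.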